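The source may report more compounds than this note shows. Statements on the series, on what has been measured and on what is new or still open speak of the compounds shown alone.

Measured compounds:
compound 1, `COc1ccc2nccc(CC[C@H]3OC[C@H](NCc4cc5c(cn4)OCCO5)CO3)c2c1`: 40000 nM
compound 2, `COc1ccc2nccc(CC[C@H]3CC[C@H](NCc4ccc(Cl)c(Cl)c4)CC3)c2c1`: "not determined" (no result reported)
compound 3, `COc1ccc2nccc(CC[C@H]3CC[C@H](NCc4ccc5c(n4)NC(=O)CO5)CC3)c2c1`: 12000 nM

In an ADME assay on K562 cells (Homo sapiens) for antiproliferative activity (on this read-out higher numbers stand for weaker inhibition and lower numbers for stronger inhibition), compound 3 gives 12000 nM and holds the lowest number of the two that were reported. Its nearest neighbour on this read-out is compound 1, for which this assay gave 40000 nM, a gap beyond the usual scatter. Within the data shown here, compound 2 was run without a reported number, so only two compounds frame the comparison.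

The unmeasured compound 4, `COc1ccc2nccc(CC[C@H]3CC[C@H](NCc4ccc5c(c4)OCCO5)CC3)c2c1`, differs from compound 3 by one change: a group of 10 heavy atoms (8 carbon, 2 oxygen; one six-membered non-aromatic ring with 2 hetero atoms, one six-membered aromatic ring of carbon only) in place of a group of 11 heavy atoms (7 carbon, 2 nitrogen, 2 oxygen; one six-membered non-aromatic ring with 2 hetero atoms, one six-membered aromatic ring with 1 hetero atom), on a saturated chain carbon bound to an amine nitrogen

No step between two measured compounds isolates this change, so the direction of the move in this assay is not fixed by any shown pair. Compound 1, which carries a different core, sits above compound 3, and on that thin basis a modest rise in the number, that is a somewhat weaker inhibition, is expected for compound 4, of a size estimated as a 1.7-fold higher number from compound 3 to compound 4 (0.22 log units; within the scatter). Compound 4 is expected to give about 20000 nM in this assay, within a range of 6000 nM to 60000 nM.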

Compound 4, half-maximal inhibitory concentration: 4200 nM
Estimate against measurement, compound 4: 4.8-fold (0.68 log units) above; measured number below the stated range.
By their numbers in this assay, from the lowest: compound 4; then compound 3; then compound 1.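

Among these compounds, on the saturated chain carbon bound to an amine nitrogen, the earlier compounds offered no pair that isolated this group, whereas in this assay placing 2,3-dihydro-1,4-benzodioxin-6-yl there gives a 2.9-fold lower number from compound 3 to compound 4 (0.46 log units; beyond the scatter). The direction is therefore now fixed on this core: inhibition is stronger with the aromatic ring of carbon only, and the group that enters has no hydrogen-bond donor, while the group that leaves has 1. These differences arrive together in a single step, so the result cannot assign the shift to any one of them, and nothing measured accounts for it.

Going by these compounds, whether a fluorine or a nitrile on the aromatic ring of the entering group would move the number further remains open. So does whether the same exchange on the core of compound 1 would act in the same direction.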